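Working notes: methoxy step and cytotoxicity in the series

The source may hold more compounds than are shown below. What is called first, only, known or untested is meant among the compounds shown, and "the series" means these compounds.

Measured compounds:
compound 1 `O=C(CCc1cccc2c1B(O)OC2)Nc1ccccc1`, in an ADME assay on WI-38 cells (Homo sapiens) for cytotoxicity, read by MTT assay, with a stated time of 72 h (on this read-out higher numbers stand for weaker inhibition and lower numbers for stronger inhibition), compound 1 gives 30000 nM.
compound 2 `COc1ccc(NC(=O)CCc2cccc3c2B(O)OC3)cc1`; in this assay compound 2 reaches only a limit, > 100000 nM.
compound 3 `COc1cccc(-c2cccc(NC(=O)CCc3cccc4c3COB4O)c2)c1`; in this assay compound 3 also reaches only a limit, > 100000 nM.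

Going by the values given here, the one measured step, an at least 3.3-fold higher number from compound 1 to compound 2 (0.52 log units; beyond the scatter), comes from the change (methoxy in place of hydrogen on an aromatic carbon). How the core of compound 1 and the core of compound 3 differ is not broken down here.

Compound 4 `COc1cc(OC)cc(-c2cccc(NC(=O)CCc3cccc4c3COB4O)c2)c1`, not yet measured, differs from compound 3 by methoxy in place of hydrogen on an aromatic carbon. This is the same kind of change as between compound 1 and compound 2, not the same: in compound 2 the methoxy sits para to a large group, in compound 4 meta to a large group and meta to a methoxy group.

For compound 4 a step that the limit leaves unreadable from compound 3 to compound 4 is expected, which rests on the weaker-inhibition direction of the earlier step and on the fact that compound 3 already sits at the limit of > 100000 nM in this assay, at which 2 of the 3 values shown sit. Compound 4 is therefore expected at roughly 150000 nM, between 60000 nM and 400000 nM, most likely reported again as a limit only.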

Compound 4, half-maximal inhibitory concentration: > 100000 nM
Compound 4: only a limit was reported; the forecaster's own chance of this, stated with the estimate: 85%; the middle value lies beyond the limit too.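

No new step can be read between compound 3 and compound 4: in this assay both reach only a limit, so the change from 3-methoxyphenyl to 3,5-dimethoxyphenyl has no readable size. The compounds shown leave open where the actual values of compound 3 and compound 4 lie, and whether the added methoxy shifts them at all.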